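Swapping Bromo for Methyl on the Aryl Piperazine

A few compounds are considered here, and "the series" means these few. Any claim that something is new, unique, unknown or untested is made for them only; others in the source may bear on it.

Compound 1 `CCCn1c(=O)[nH]c2nc(-c3ccc(S(=O)(=O)N4CCN(c5ccccc5Br)CC4)cc3)[nH]c2c1=O` gives 20% in an assay on CHO cells for displacement of a labelled ligand from adenosine receptor A3 (Homo sapiens), read by scintillation counting, with a stated time of 45 min, tested at 1 uM, in the presence of a further agent that is not named here (a lower number here means less inhibition, a higher number more inhibition at the concentration tested (going by the name of the read-out)), the higher of the two measured numbers. Compound 2 `CCCn1c(=O)[nH]c2nc(-c3ccc(S(=O)(=O)N4CCN(c5ccccc5)C(C)C4)cc3)[nH]c2c1=O` gives -2% in this assay, a gap beyond the usual scatter below compound 1. Compound 3 `CCCn1c(=O)[nH]c2nc(-c3ccc(S(=O)(=O)N4CCN(c5ccccc5C)CC4)cc3)[nH]c2c1=O` has not yet been measured; it differs from compound 1 by methyl in place of bromo on an aromatic carbon. Going by the values given here, no measured pair shows this particular change, so its effect is unknown from the data at hand. The step of a number 5 percentage points lower from compound 1 to compound 3 (within the scatter) is expected to stay within the usual scatter, in either direction. Compound 3 is estimated at 15%, with a range from -5% to 35%.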

Compound 3, a percentage reported as inhibition, at one concentration (the size of the read-out at that concentration, not a potency): 25%
Compound 3: the middle estimate sits 10 percentage points below what was measured; low and high end bracket the measured number.
By their numbers in this assay, from the lowest: compound 2; then compounds 1 and 3 (each within the scatter of the next).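

In this assay, putting methyl in place of bromo on this aromatic carbon gives a number 5 percentage points higher from compound 1 to compound 3 (within the scatter), so the change from 2-bromophenyl to 2-methylphenyl cannot be told apart from repeat-to-repeat scatter. At this place on the ring, then, either group is compatible with a similar reading at the single concentration tested. Nothing available explains this result. Still open, on these data alone, is how a methoxy group, an amine or a carboxylic acid would read at this same place.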